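Adding a methoxy to compound 2: an expected small step

A few compounds are considered here, and "the series" means these few. Any claim that something is new, unique, unknown or untested is made for them only; others in the source may bear on it.

Of the compounds shown here, three sharing one core have been tested in a functional assay on A549 cells (Homo sapiens) for antiproliferative activity, with a stated time of 72 h; a higher number here means a weaker inhibitor, a lower number a stronger inhibitor. Compound 1 `COc1ccc(C2=NN(c3nc(-c4ccccc4)c(C#N)c(=O)n3C)C(c3ccc(OC)cc3)C2)cc1` gives 26500 nM. Compound 2 `COc1ccc(C2CC(c3ccccc3)=NN2c2nc(-c3ccc(Cl)cc3)c(C#N)c(=O)n2C)cc1` gives 23800 nM, and compound 3 `Cn1c(N2N=C(c3ccccc3)CC2c2ccc(F)cc2)nc(-c2ccc(Cl)cc2)c(C#N)c1=O` gives 27800 nM. Compound 2 carries the lowest of the three numbers, yet both neighbours sit within the scatter of it, so no order among the three can be read from these values. Among the compounds with values here, the one single-point step measured so far, a 1.2-fold higher number from compound 2 to compound 3 (0.07 log units; within the scatter), exchanges a methoxy for a fluoro on an aromatic carbon and leaves the read-out essentially unchanged. Compound 1 and compound 2 differ in another place, and their two values likewise show no separation.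

Compound 4 `COc1ccc(C2=NN(c3nc(-c4ccc(Cl)cc4)c(C#N)c(=O)n3C)C(c3ccc(OC)cc3)C2)cc1` derives from compound 2 by the change (methoxy in place of hydrogen on an aromatic carbon), methoxy in place of hydrogen on an aromatic carbon, para to a large group. Within the data shown here, no measured step touches this position; the step from compound 2 to compound 3 concerns a different group elsewhere and was itself within the scatter. With the only relevant observation being that aryl substituent changes have so far moved nothing, the expected step in this assay is a 1.0-fold higher number from compound 2 to compound 4 (0.00 log units; within the scatter), that is none beyond the scatter. Compound 4 is therefore estimated at 24000 nM, within a range of 12000 nM to 48000 nM.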

Compound 4, half-maximal inhibitory concentration: 39700 nM
Beside the measured number, compound 4's estimate is 1.7-fold (0.22 log units) below it; measured number inside the range.
By their numbers in this assay, from the lowest: compounds 2, 1, 3 and 4 (each within the scatter of the next).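

In this assay, within the data shown here, the position para to a large group, which no earlier step touched, takes the change from phenyl to 4-methoxyphenyl with a 1.7-fold higher number from compound 2 to compound 4 (0.22 log units; within the scatter), so adding this methoxy gives no separation that can be read, although this is a larger step than the one measured between compound 2 and compound 3. Among these compounds, the second new step, chloro in place of hydrogen on an aromatic carbon, is the first measured exchange of that kind, and with a 1.5-fold higher number from compound 1 to compound 4 (0.18 log units; within the scatter) it too stays inside the scatter, so with the methoxy already in place on this ring, the chloro adds no separation either. No measurement bears on why these steps remain so small, and the data offer no account of it.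

On these data alone, every step among the four compounds lies within the scatter, so it remains open whether this position can move the read-out at all, and only a hydrogen and a methoxy are seen there. An amine or a carboxylic acid at the same place, or a longer chain in place of the methoxy, would test whether the flat picture holds for groups of another kind.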